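This account rests on a few compounds, and the source may have more. Where it says the series, first, only, none or still open, it means among the compounds named here.

Compound 1 `C[C@H](c1ccccc1)N1C(=O)O[C@](Cc2ccccc2)(c2ncc(-c3ccccc3)[nH]2)C1=O` is the starting point of this small set. In an ADME assay (liver) for metabolic stability, with Liver microsome (Rattus norvegicus) as the target, using microsomes, with a stated time of 0.5 h, tested at 1 uM (on this read-out lower numbers stand for a less stable compound and higher numbers for a more stable compound), compound 1 gives 4%. Compound 2 `C[C@H](c1ccccc1)N1C(=O)O[C@](Cc2ccccc2)(c2ncc(Cc3ccccc3)[nH]2)C1=O` differs from it by benzyl in place of phenyl on an aromatic carbon, and in this assay compound 2 gives 0%, so the step runs a number 4 percentage points lower from compound 1 to compound 2 (within the scatter). Compound 3 `C[C@H](c1ccccc1)N1C(=O)O[C@](Cc2ccccc2)(c2nnc(-c3ccccc3)o2)C1=O` carries a different core; the difference from compound 1 is 5-phenyl-1,3,4-oxadiazol-2-yl in place of 5-phenyl-1H-imidazol-2-yl on a saturated ring carbon. In this assay compound 3 gives 0%, and the step is a number 4 percentage points lower from compound 1 to compound 3 (within the scatter). Compounds 2 and 3 stand level at the digits shown, together the lowest of the three numbers.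

Compound 4 `C[C@H](c1ccccc1)N1C(=O)O[C@](Cc2ccccc2)(c2nnc(Cc3ccccc3)o2)C1=O` has not yet been measured. It differs from compound 3 by benzyl in place of phenyl on an aromatic carbon, the same kind of change as from compound 1 to compound 2, though not the same: in compound 3 the place is on a five-membered aromatic ring with 2 nitrogen and 1 oxygen, next to the ring oxygen, whereas in compound 1 the ring holds 2 nitrogen only. Because the earlier step was a number 4 percentage points lower from compound 1 to compound 2 (within the scatter), the expected step for compound 4 is no change at the digits printed from compound 3 to compound 4 (within the scatter). Compound 4 is therefore estimated at 0%, between 0% and 8%.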

Compound 4, percent of the compound remaining: 0%
Beside the measured number, compound 4's estimate shows no gap at the digits printed; the range from low to high includes it.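

In this assay, benzyl in place of phenyl on an aromatic carbon of the five-membered aromatic ring with 2 nitrogen and 1 oxygen shows no change at the digits printed from compound 3 to compound 4 (within the scatter). Set beside the same change on the core of compound 1, the two steps cannot be told apart: the same change on two cores in this assay, a number 4 percentage points lower (within the scatter) from compound 1 to compound 2 and no change at the digits printed (within the scatter) from compound 3 to compound 4, 4 percentage points apart, within the scatter of two such steps This shows that the change carries across these two cores without a detectable difference, but it does not show that the change has no effect on stability or that the two cores respond alike: compound 3 stands at 0%, the bottom of the read-out, and agreement at that level says little about how the change would behave on a more stable compound.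

The compounds shown leave open whether an amine, a carboxylic acid or a longer chain in place of benzyl would leave more of the compound remaining. They also leave open whether any core carrying these groups would reach a level at which the step between phenyl and benzyl could be read.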